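The compounds below may be only part of what the source reports. "The series", "measured", "known", "first", "only" and "open" are said of these compounds alone.

Measured in an ADME assay on PBMC cells (Homo sapiens) for cytotoxicity, read by MTT assay, with a stated time of 72 h, in the absence of a further agent; a higher number here means a weaker inhibitor, a lower number a stronger inhibitor:

Compound 1, `COc1ccc(Nc2cccnc2)cc1`, gives 96000 nM.
Compound 2, `Cc1ccc(-c2ccnc(Nc3ccc(F)cc3)c2)cc1`, gives 127000 nM.
Compound 3, `Fc1ccc(Nc2ccc3ccccc3n2)cc1`, gives 90000 nM.

Compound 2 stands at the highest of the three numbers, yet neither neighbour is separated from it: the number of compound 1 lies closest to it and that of compound 3 furthest away, and both gaps fall within the usual scatter of repeated measurements. The three compounds are therefore not told apart in this assay; all of them are weak.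

Compound 4, `COc1ccc(Nc2cc(-c3ccc(C)cc3)ccn2)cc1`, has not yet been measured. It differs from compound 2 in one place: methoxy in place of fluoro on an aromatic carbon.

Among the measured compounds shown here, no pair of measured compounds shows this same change, so the step cannot be read off directly. What the measured set does offer is compound 1, which already carries a methoxy on its aniline ring and in this assay gives 96000 nM, a number within the scatter of compound 2. On that basis no step beyond the scatter is expected in either direction. The expected step is a 1.2-fold lower number from compound 2 to compound 4 (0.06 log units; within the scatter). Compound 4 is estimated at 110000 nM in this assay, with a range from 55000 nM to 220000 nM.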

Compound 4, half-maximal inhibitory concentration: 52000 nM
For compound 4 the middle estimate is 2.1-fold (0.33 log units) above the measured one; measured number below the stated range.
By their numbers in this assay, from the lowest: compounds 4, 3, 1 and 2 (each within the scatter of the next, the first and the last beyond it).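

In this assay, putting methoxy in place of fluoro on an aromatic carbon, para to a large group, gives a 2.4-fold lower number from compound 2 to compound 4 (0.39 log units; beyond the scatter). Among the compounds shown here, this is the first step in the set that can be read at all, and it shows that this position on the six-membered aromatic ring of carbon only is not silent: a change of a single substituent there moves the number beyond the scatter, though only modestly. The data carry no measurement that would explain the step, so it stands as an observation about this one pair of compounds.

Since the finding rests on that single pair, the compounds shown leave open whether the same change would give a step of like size on another core. They also leave open how far the number would move with a different group at this place, such as chloro, an amine or a longer chain like ethoxy, and whether any such group would carry it further in the direction of compound 4 or back towards compound 2.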